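Swapping tert-butyl for trifluoromethoxy on a shared core

The compounds below may be only part of what the source reports. "The series", "measured", "known", "first", "only" and "open" are said of these compounds alone.

Measured compounds:
compound 1, `COc1cccc(Nc2nc3nonc3nc2O)c1`: 75400 nM
compound 2, `Oc1nc2nonc2nc1Nc1ccccc1`: 66700 nM
compound 3, `CC(C)(C)c1cccc(Nc2nc3nonc3nc2O)c1`: 2200 nM

In an assay on mitochondria from L6 cells (Rattus norvegicus) for activation, with a stated time of 90 min (on this read-out higher numbers stand for an effect only at larger amounts of compound and lower numbers for an effect already at smaller amounts), compound 3 has the lowest number of the three; the step of a 30-fold lower number from compound 2 to compound 3 (1.48 log units; beyond the scatter) and the step of a 34-fold lower number from compound 1 to compound 3 (1.53 log units; beyond the scatter) are both large. Compound 4, `Oc1nc2nonc2nc1Nc1cccc(OC(F)(F)F)c1`, differs from compound 3 in one place: trifluoromethoxy in place of tert-butyl on an aromatic carbon. The two steps into compound 3 bear on this change: methoxy and hydrogen in that place gave numbers close to each other, and only tert-butyl gave the low number. Taking tert-butyl away is therefore expected to move the number upward; no measured step tells how far trifluoromethoxy goes, so the expected step of a 6.8-fold higher number from compound 3 to compound 4 (0.83 log units; beyond the scatter) carries a wide range. For compound 4 the estimated value is 15000 nM, expected between 4000 nM and 55000 nM.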

Compound 4, half-maximal effective concentration: 5100 nM
For compound 4 the middle estimate is 2.9-fold (0.47 log units) above the measured one; the measured number falls inside the stated range.
By their numbers in this assay, from the lowest: compound 3; then compound 4; then compounds 2 and 1 (each within the scatter of the next).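

In this assay the low number turns out not to belong to tert-butyl alone: putting trifluoromethoxy in its place gives only a 2.3-fold higher number from compound 3 to compound 4 (0.37 log units; beyond the scatter) and so keeps most of the gain. Against hydrogen in the same place, trifluoromethoxy gives a 13-fold lower number from compound 2 to compound 4 (1.12 log units; beyond the scatter) as a large step. Exchanging the methyl on the oxygen for trifluoromethyl gives a 15-fold lower number from compound 1 to compound 4 (1.17 log units; beyond the scatter) as another large step, so this small change separates two very different numbers.

As far as these compounds go, whether an amine, a carboxylic acid or a longer chain in this place would also give a low number remains open. Nothing shown here explains the differences between these groups.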